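The source may hold more compounds than are shown below. What is called first, only, known or untested is meant among the compounds shown, and "the series" means these compounds.

Measured so far:
- compound 1, `CC(C)C(C(N)=O)c1ccc(Cl)cc1`: < 30%
- compound 2, `CC(C)[C@H](C(=O)Nc1nnc(C(F)(F)F)s1)c1ccc(Cl)cc1`: 115%

Compound 1 stands at the bottom of the range in a functional assay on CHO cells for agonist activity at Free fatty acid receptor 2 (Homo sapiens), read by cAMP accumulation; a lower number here means a smaller maximal response, a higher number a larger maximal response. Its value of < 30% in this assay is a limit, not a number, as the limit of < 30% in this assay, at which 1 of the 2 values shown sits, states. Compound 2, which carries a heteroaryl group on the amide nitrogen, gives 115% in this assay, so the two values differ by more than the usual scatter.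

Compound 3, `CC(C)C(C(=O)Nc1nnn[nH]1)c1ccc(Cl)cc1`, has not been measured in this assay. It differs from compound 1 by 1H-tetrazol-5-yl in place of hydrogen on an amide-type nitrogen, so the amide nitrogen again bears a five-membered aromatic ring rather than a hydrogen, as in compound 2.

Compound 1 sits at its limit in this assay. Given that compound 2 gives 115%, a large upward step is expected for the change from compound 1 to compound 3, well beyond the scatter. Compound 3 is therefore expected to give 90% in this assay, between 50% and 120%, a rise of a number at least 60 percentage points higher from compound 1 to compound 3 (beyond the scatter) estimated from compound 1.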

Compound 3, largest response reached (reported as efficacy), in percent of the reference or control that the assay uses: < 30%
Compound 3: only a limit was reported; the forecaster's own chance of this, stated with the estimate: 15%; middle value at least 60 percentage points from the limit.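

No step from compound 1 to compound 3 can be read in this assay, as both values are limits, not numbers: the limit of < 30% in this assay, at which 2 of the 3 values shown sit.

The compounds shown leave open what maximal response compound 1 and compound 3 actually give, and which groups on the amide-type nitrogen raise it.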